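Methoxymethyl to ethoxymethyl on the benzyl side chain

This account rests on a few compounds, and the source may have more. Where it says the series, first, only, none or still open, it means among the compounds named here.

Measured compounds:
compound 1 `CCCC[C@H](C)C[C@H](O)/C=C/[C@H]1[C@H](O)CC(=O)[C@@H]1SCCCCCC(=O)O` gives 0.4 nM in an assay on CHO cells for displacement of a labelled ligand from prostaglandin E2 receptor EP4 subtype (Mus musculus); on this read-out lower numbers stand for stronger inhibition and higher numbers for weaker inhibition;
compound 2 `COCc1cccc(C[C@H](O)/C=C/[C@H]2[C@H](O)CC(=O)[C@@H]2SCCCSCC(=O)O)c1` gives 3.1 nM in this assay.

Of the two numbers, compound 2 stands higher, with compound 1 the nearer neighbour; the gap between them is beyond the scatter. Compound 3 `CCOCc1cccc(C[C@H](O)/C=C/[C@H]2[C@H](O)CC(=O)[C@@H]2SCCCSCC(=O)O)c1` differs from compound 2 only by methyl in place of hydrogen on a saturated chain carbon bound to an oxygen on a saturated carbon. Within the data shown here, no step between two measured compounds resembles this change, so no direction can be drawn from the data; a step of no more than the scatter is expected, in either direction. For compound 3 the estimate in this assay is 3 nM, in the range 1 nM to 9 nM, which means a step of a 1.0-fold lower number from compound 2 to compound 3 (0.01 log units; within the scatter).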

Compound 3, inhibition constant: 9.4 nM
The estimate for compound 3 lay 3.1-fold (0.50 log units) below the measured number; the measured number lies above the stated range.
By their numbers in this assay, from the lowest: compound 1; then compound 2; then compound 3.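

Methoxymethyl to ethoxymethyl is the first single change read at this position, and in this assay the added methyl on the saturated chain carbon bound to an oxygen gives a modest rise beyond the scatter (a 3.0-fold higher number from compound 2 to compound 3 (0.48 log units; beyond the scatter)). The position is therefore sensitive to even this small extension, and the change moves the number towards weaker inhibition. Nothing available explains the rise. From the compounds shown here alone, what remains open is whether a longer chain such as propoxymethyl raises the number further, and whether hydroxymethyl or an amine in this place would lower it.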